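The compounds below may be only part of what the source reports. "The series", "measured", "known", "first", "only" and "open" are said of these compounds alone.

Compound 3 `Cc1cc(-c2ccoc2)c2ncc(CSCCc3ccccc3)n2c1` gives 64 ug/mL in an ADME assay on HEL cells (Homo sapiens) for cytotoxicity, with a stated time of 3 days (on this read-out lower numbers stand for higher toxicity in this test and higher numbers for lower toxicity in this test), the highest of the three numbers available. Compound 1 `Cc1cc(-n2ccnc2)cn2c(CSCCc3ccccc3)cnc12` gives 23 ug/mL in this assay, and compound 2 `Cc1cc(-n2ccc3ccccc32)cn2c(CSCCc3ccccc3)cnc12` gives 18 ug/mL in this assay; both gaps from compound 3 lie beyond the scatter. Compound 4 `Cc1cc(Sc2ccc(Cl)cc2)c2ncc(CSCCc3ccccc3)n2c1` has not been measured yet; it differs from compound 3 by (4-chlorophenyl)sulfanyl in place of furan-3-yl on an aromatic carbon. Among the measured compounds shown here, the only measured step, a 1.3-fold lower number from compound 1 to compound 2 (0.11 log units; within the scatter), exchanged one aromatic group for another and stayed within the scatter, so a swap of this kind has not so far moved the read-out much. No measured step exchanges furan-3-yl for (4-chlorophenyl)sulfanyl, and nothing among these compounds shows how a sulfur or a chlorine in this place behaves. Since compound 3 stands above the other two, the expected direction for compound 4 is a modest move back toward their numbers, though a change within the scatter is equally plausible. The estimate for compound 4 is 35 ug/mL, within 15 ug/mL to 80 ug/mL. This estimate means that a 1.8-fold lower number from compound 3 to compound 4 (0.26 log units; within the scatter) is expected.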

Compound 4, half-maximal cytotoxic concentration: 100 ug/mL
The estimate for compound 4 lay 2.9-fold (0.46 log units) below the measured number; the measured number lies above the stated range.
By their numbers in this assay, from the lowest: compounds 2 and 1 (each within the scatter of the next); then compounds 3 and 4 (each within the scatter of the next).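

Putting (4-chlorophenyl)sulfanyl in place of furan-3-yl on this aromatic carbon, meta to a methyl group, gives a 1.6-fold higher number from compound 3 to compound 4 (0.19 log units; within the scatter) in this assay. The two compounds therefore cannot be told apart in this test, even though the entering group has 8 heavy atoms against 5 and brings a sulfur and a chlorine to this place for the first time among these compounds. No supporting measurement is available to explain why the read-out stays so close across this exchange. Going by these compounds, it remains open whether a group without an aromatic ring at this place, such as an amine, a carboxylic acid or a longer carbon chain, would keep the number in this range. Also open, on these data alone, is how much of this result belongs to the sulfur and how much to the chlorine, which a phenylsulfanyl group, lacking the chlorine, could help separate.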